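A few compounds are considered here, and "the series" means these few. Any claim that something is new, unique, unknown or untested is made for them only; others in the source may bear on it.

- Compound 1 `C=C1CCC[C@]2(C)CCC(c3cn(-c4ccc(I)cc4)nn3)=CC[C@@]12C`: 145000 nM
- Compound 2 `C=C1CCC[C@]2(C)CCC(c3cn(-c4cccc(OC)c4)nn3)=CC[C@@]12C`: 38900 nM

In a functional assay on DU-145 cells (Homo sapiens) for cytotoxicity, read by MTT assay, with a stated time of 48 h (a lower number here means a stronger inhibitor, a higher number a weaker inhibitor), compound 2 gives 38900 nM, the lower of the two numbers, which makes it the stronger inhibitor of this pair. Compound 3 `C=C1CCC[C@]2(C)CCC(c3cn(-c4ccc(C)cc4)nn3)=CC[C@@]12C` differs from it in one group: 4-methylphenyl in place of 3-methoxyphenyl on an aromatic nitrogen. In words, 4-methylphenyl stands in place of 3-methoxyphenyl on an aromatic nitrogen. For the measured compounds named here, the only measured step, a 3.7-fold lower number from compound 1 to compound 2 (0.57 log units; beyond the scatter), changed this same group. It left 4-iodophenyl, and 4-methylphenyl is again a 4-substituted group, so part of that step may be lost. The expected change, a modest move toward a higher number in this assay, is a 1.9-fold higher number from compound 2 to compound 3 (0.29 log units; within the scatter). Compound 3 is estimated at 75000 nM, with an expected range from 25000 nM to 170000 nM.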

Compound 3, half-maximal inhibitory concentration: 132000 nM
Compound 3: middle estimate off by 1.8-fold (0.25 log units), on the low side; the measured number falls inside the stated range.
By their numbers in this assay, from the lowest: compound 2; then compounds 3 and 1 (each within the scatter of the next).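

Changing 3-methoxyphenyl to 4-methylphenyl gives a 3.4-fold higher number from compound 2 to compound 3 (0.53 log units; beyond the scatter), so the gain seen with 3-methoxyphenyl does not carry over to this group. Methyl in place of iodo gives a 1.1-fold lower number from compound 1 to compound 3 (0.04 log units; within the scatter), so that exchange leaves the number in this assay essentially unmoved. Compound 2 alone stands apart from the other two, and no available data explain this difference.

These compounds do not separate the effect of the methoxy group from that of its location on the six-membered aromatic ring. On these data alone, how an amine or a carboxylic acid on that ring would read also remains open.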